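The source may hold more compounds than are shown below. What is called first, only, known or untested is meant among the compounds shown, and "the series" means these compounds.

In a functional assay on KB cells (Homo sapiens) for inhibition (on this read-out higher numbers stand for weaker inhibition and lower numbers for stronger inhibition), compound 1 `CCOC(=O)c1cn([C@@H]2O[C@H](CO)[C@@H](O)[C@H]2O)c2nnnc(N)c12` gives 80000 nM. Compound 3 `Cc1ccc(C(=O)OC[C@H]2O[C@@H](n3cc(C(N)=O)c(C(N)=O)c3N)C[C@@H]2OC(=O)c2ccc(C)cc2)cc1` gives 100000 nM, which lies within the scatter of the number for compound 1, so the two stand level. Compound 2 `CN(N)c1nnnc2c1c(C#N)cn2[C@@H]1O[C@H](COC(=O)c2ccccc2)[C@@H](OC(=O)c2ccccc2)[C@H]1OC(=O)c1ccccc1` reads > 10000 nM, which is a limit of the assay and not a number. In compound 4 `COC(=N)c1cn([C@@H]2O[C@H](CO)[C@@H](O)[C@H]2O)c2nnnc(N)c12` the ethoxycarbonyl of compound 1 is replaced on an aromatic carbon: a group of 4 heavy atoms (2 carbon, 1 nitrogen, 1 oxygen; no ring) in place of a group of 5 heavy atoms (3 carbon, 2 oxygen; no ring), on an aromatic carbon. For the measured compounds named here, no measured pair here shows this change, so the expectation is loose. A step toward stronger inhibition in this assay, beyond the scatter, is expected, and the estimate for it is an 8.0-fold lower number from compound 1 to compound 4 (0.90 log units; beyond the scatter). For compound 4 the estimated value is 10000 nM, with an expected range from 700 nM to 100000 nM.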

Compound 4, half-maximal inhibitory concentration: 20000 nM
Estimate against measurement, compound 4: 2.0-fold (0.30 log units) below, within the range that was stated.
By their numbers in this assay, from the lowest: compound 4; then compounds 1 and 3 (each within the scatter of the next).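

In this assay, the aromatic carbon two ring bonds from the ring nitrogen proves sensitive to the group it carries, giving the first step that can be read among these compounds: a 4.0-fold lower number from compound 1 to compound 4 (0.60 log units; beyond the scatter). Replacing the ethoxycarbonyl with a slightly smaller group that has a hydrogen-bond donor is therefore enough to move the number beyond the scatter. Nothing measured here accounts for this step.

On these data alone, it remains open whether the donor or the smaller group drives the step. As far as these compounds go, how a carboxylic acid or an amine at this position would read on the core of compound 1 also remains open.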